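The source may report more compounds than this note shows. Statements on the series, on what has been measured and on what is new or still open speak of the compounds shown alone.

Measured so far:
compound 1, `COc1ccccc1CNc1nc(N)nc(-c2ccccc2CO)n1`, gives 3.99 in a functional assay on cells for positive allosteric modulation of G-protein coupled receptor 68 (Homo sapiens), read by a luciferase reporter and cAMP accumulation, with a stated time of 30 min, at pH 6.8 and pH 8.3, in the presence of a further agent that is not named here; a lower number here means a less potent compound, a higher number a more potent compound, by a factor of ten per unit of this negative logarithm
compound 2, `Nc1nc(NCCCc2ccccc2)nc(-c2ccccc2CO)n1`, gives 5.22
compound 3, `COc1ccccc1CNc1nc(N)nc(-c2c(F)cccc2CO)n1`, gives 4.11

Compound 3 differs from compound 1 by fluoro in place of hydrogen on an aromatic carbon; the step is a number 0.12 log units higher from compound 1 to compound 3 (within the scatter), so the two cores give numbers that cannot be told apart. Within the data shown here, compound 2 differs from compound 1 by phenethyl in place of 2-methoxyphenyl on a saturated chain carbon bound to a nitrogen on an aromatic ring, and here the step is a number 1.23 log units higher from compound 1 to compound 2 (beyond the scatter), the only step among the three that stands out.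

Compound 4, `Nc1nc(NCCCc2ccccc2)nc(-c2c(F)cccc2CO)n1`, is not yet measured. It differs from compound 3 by phenethyl in place of 2-methoxyphenyl on a saturated chain carbon bound to a nitrogen on an aromatic ring, which is the same change as that from compound 1 to compound 2, at the same place word for word; the two cores differ only by fluoro in place of hydrogen on an aromatic carbon.

For compound 4 a step of about a number 1.19 log units higher from compound 3 to compound 4 (beyond the scatter) is expected, resting on the step from compound 1 to compound 2 of a number 1.23 log units higher from compound 1 to compound 2 (beyond the scatter) and on the near-equal footing of the cores shown by a number 0.12 log units higher from compound 1 to compound 3 (within the scatter). Starting from compound 3, which gives 4.11, the estimate for compound 4 is 5.3, expected to fall between 4.8 and 5.8.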

Compound 4, negative logarithm of the antagonist equilibrium constant: 4.47
Estimate against measurement, compound 4: 0.83 log units above; measured number below the stated range.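

In this assay, phenethyl in place of 2-methoxyphenyl still raises the number on the fluoro-bearing core, with a number 0.36 log units higher from compound 3 to compound 4 (beyond the scatter), but the step does not keep the size it had on the core of compound 1: the same change on two cores in this assay, a number 1.23 log units higher (beyond the scatter) from compound 1 to compound 2 and a number 0.36 log units higher (beyond the scatter) from compound 3 to compound 4, 0.87 log units apart, beyond the scatter of two such steps

Seen from the other side, fluoro in place of hydrogen on an aromatic carbon has no readable effect in the 2-methoxyphenyl pair but gives a number 0.75 log units lower from compound 2 to compound 4 (beyond the scatter) in the phenethyl pair: the same change on two cores in this assay, a number 0.12 log units higher (within the scatter) from compound 1 to compound 3 and a number 0.75 log units lower (beyond the scatter) from compound 2 to compound 4, 0.87 log units apart, beyond the scatter of two such steps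

These four compounds form a single square, so the two gaps are one finding seen twice: the direction of the phenethyl change carries across the two cores and its size does not, while nothing here shows why or how it would behave on a third core.

As far as these compounds go, it remains open whether chloro or methyl in place of the fluoro would shrink the step in the same way. From the compounds shown here alone, it is also open whether a longer chain than phenethyl, or an amine within that chain, would follow phenethyl on both cores.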